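The source may hold more compounds than are shown below. What is called first, only, known or untested is meant among the compounds shown, and "the series" means these compounds.

Working notes on the series, read in a functional assay on the whole organism (strain Kunming) with Mus musculus as the target, with a stated time of 0.5 h; on this read-out lower numbers stand for an effect already at smaller amounts and higher numbers for an effect only at larger amounts of compound. Among the measured compounds shown here, compound 1 `COc1ccccc1/C=C/C(=O)OC/C=C/c1cc(OC)c(OC)cc1OC` gives 780 umol/kg, the only actual number so far. Compound 2 `COc1cc(OC)c(OC)cc1/C=C/COC(=O)/C=C/c1ccc(OC)c(OC)c1` reports > 723 umol/kg, which is a limit and not a number. Compound 3 `COc1cc(OC)c(OC)cc1/C=C/COC(=O)/C=C/c1ccccc1C(F)(F)F` reports > 710 umol/kg, which is also a limit and not a number, so its position can be read only from that limit.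

The change to compound 4 `COc1cc(OC)c(OC)cc1/C=C/COC(=O)/C=C/c1cccc(Br)c1` is 3-bromophenyl in place of 2-(trifluoromethyl)phenyl on a double-bonded chain carbon bound to a double-bonded chain carbon. The measured steps that bear on it are a step that the limit leaves unreadable from compound 1 to compound 2, a step that the limit leaves unreadable from compound 1 to compound 3 and a step that the two limits leave unreadable from compound 2 to compound 3. None of them has a readable size, so they give no measure for this change. No step beyond the usual scatter is expected in this assay, and no direction is favoured. For the measured compounds named here, the expectation is anchored on compound 1 at 780 umol/kg, the one number available. The expected step is a step that the limit leaves unreadable from compound 3 to compound 4. A limit is expected to be somewhat more likely than a number. For compound 4 the estimated value is 750 umol/kg, with an expected range of 400 umol/kg to 1200 umol/kg.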

Compound 4, dose for half-maximal effect: 497 umol/kg
Estimate against measurement, compound 4: 1.5-fold (0.18 log units) above; the range from low to high includes it.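

Compound 4 gives the series a second actual number in this assay, and with it the first floors of known size for a change at this position: there is an at least 1.4-fold lower number from compound 3 to compound 4 (0.15 log units; that floor lies within the scatter) and there is an at least 1.4-fold lower number from compound 2 to compound 4 (0.16 log units; that floor lies within the scatter). Among the compounds shown here, the one step between two actual numbers is a 1.6-fold lower number from compound 1 to compound 4 (0.20 log units; within the scatter), so 3-bromophenyl in place of 2-methoxyphenyl does not separate compound 4 from compound 1. Compound 3 remains a limit, so the full size of its step stays unread: the limit of > 710 umol/kg in this assay, at which 1 of the 4 values shown sits.

On these data alone, compound 2 also remains a limit, and the steps among the first three compounds cannot be read: the limit of > 723 umol/kg in this assay, at which 1 of the 4 values shown sits. How a phenyl carrying an amine or a carboxylic acid would read on the same double-bonded chain carbon stays open.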